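A few compounds are considered here, and "the series" means these few. Any claim that something is new, unique, unknown or untested is made for them only; others in the source may bear on it.

In an ADME assay (Rattus norvegicus) for pharmacokinetics (a higher number here means faster removal of the compound, a lower number slower removal), compound 1 `Cc1c(C(F)F)nnc2sc(C(=O)NC3CN(c4ncc(C(F)(F)F)cn4)C3)c(N)c12` gives 18.8 mL/min/kg and compound 2 `Cc1c(Cl)nnc2sc(C(=O)NC3CN(c4cc(C(F)(F)F)ncc4Cl)C3)c(N)c12` gives 31.7 mL/min/kg. Compound 3 `Cc1c(CF)nnc2sc(C(=O)NC3CN(c4ncc(C(F)(F)F)cn4)C3)c(N)c12`, at 23.7 mL/min/kg, lies within the usual scatter of both, so its number cannot be ranked against theirs. Compound 4 `COc1nnc2sc(C(=O)NC3CN(c4ncc(C(F)(F)F)cn4)C3)c(N)c2c1C` changes one group of compound 3: methoxy in place of fluoromethyl on an aromatic carbon. In short, this is methoxy in place of fluoromethyl on an aromatic carbon.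

Among the measured compounds shown here, the one measured step that alters the group at this place is a 1.3-fold higher number from compound 1 to compound 3 (0.10 log units; within the scatter), with a hydrogen in place of a fluoro on the chain carbon. Compound 2 differs from compound 3 in more than one place, so it offers no clean comparison. For the measured compounds named here, no measured compound carries a methoxy, so the data give no direct test of this swap. Going by the values given here, with only that one small step as a guide, no clear shift is expected in this assay, and neither direction is favoured. The expected step is a 1.0-fold higher number from compound 3 to compound 4 (0.01 log units; within the scatter), which would stay within the scatter. Compound 4 is estimated at 24 mL/min/kg, with an expected range of 12 mL/min/kg to 45 mL/min/kg.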

Compound 4, clearance: 30.5 mL/min/kg
Compound 4: the middle estimate sits 1.3-fold (0.10 log units) below what was measured, within the range that was stated.
By their numbers in this assay, from the lowest: compounds 1, 3, 4 and 2 (each within the scatter of the next).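

Until now, this position had only been varied by the number of fluorines on a chain carbon. Compound 4 extends the comparison to a group attached through oxygen, which has one hydrogen-bond acceptor where fluoromethyl has none, yet the swap stays within the scatter in this assay (a 1.3-fold higher number from compound 3 to compound 4 (0.11 log units; within the scatter)). The comparison with the difluoromethyl group also stays within the scatter (a 1.6-fold higher number from compound 1 to compound 4 (0.21 log units; within the scatter)), so neither swap separates these groups by clearance, and no measurement here explains the small differences that are seen.

From the compounds shown here alone, whether an amine, a carboxylic acid or a longer chain such as ethoxy on this aromatic carbon would give a step beyond the scatter remains open. It is also unknown whether methoxy would behave the same way with the other end of the molecule changed, as it is in compound 2.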